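The compounds below may be only part of what the source reports. "The series", "measured", "known", "first", "only" and "open" are said of these compounds alone.

In a functional assay on HCT-116 cells (Homo sapiens) for cytotoxicity, read by MTT assay, with a stated time of 72 h (on this read-out lower numbers stand for stronger inhibition and higher numbers for weaker inhibition), three compounds have been measured so far.
Compound 1 `N[C@H]1CC[C@H](Nc2c(C(=O)NCc3ccc(F)cc3)nc(N3CCCCC3)c3cccnc23)CC1` gives 8500 nM.
Compound 2 `NCCCNc1c(C(=O)NCc2ccc(F)cc2)ncc2cccnc12` gives only a limit of the assay, > 10000 nM.
Compound 3 `COC(=O)CNc1c(C(=O)NCc2ccc(F)cc2)nc(Br)c2cccnc12` likewise gives only a limit of the assay, > 10000 nM.

Compound 3 therefore stands at the edge of what this assay can report: no number is known for it, only that it lies beyond the reported boundary, a place it shares with one other value (the limit of > 10000 nM in this assay, at which 2 of the 3 values shown sit). Compound 1 alone gives an actual number, and that number itself points to weak inhibition. Going by the values given here, none of the three measured compounds differs from another in a single place, so no measured step is available to show how far a small change can move the read-out.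

Compound 4 `O=C(NCc1ccc(F)cc1)c1nc(Br)c2cccnc2c1NCCO` is the compound still to be measured. It differs from compound 3 in one place: hydroxymethyl in place of methoxycarbonyl on a saturated chain carbon bound to a nitrogen on an aromatic ring. This is a small exchange on a short side chain, and the core and the rest of the molecule stay the same. Since compound 3 shows only a limit in this assay, the step can at best be bounded from one side.

The step that the limit leaves unreadable from compound 3 to compound 4 is expected to be none beyond the scatter. Compound 4 is accordingly expected to give about 15000 nM, within a range of 5000 nM to 40000 nM, and most probably to be reported again only as a limit.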

Compound 4, half-maximal inhibitory concentration: > 20000 nM
Compound 4 gave a limit, no number (the forecaster's own chance of this, stated with the estimate: 70%); at least 1.3-fold (0.12 log units) between middle value and limit.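

In this assay compound 4 gives only a limit of the assay, > 20000 nM. Compound 3 also gives only a limit, and the size of the step from compound 3 to compound 4, hydroxymethyl in place of methoxycarbonyl, cannot be read. The compounds shown leave open how far any single change moves the read-out: only compound 1 gives an actual number.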